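Trifluoromethyl for methyl on a sulfonamide: forecasting cytotoxicity

This account rests on a few compounds, and the source may have more. Where it says the series, first, only, none or still open, it means among the compounds named here.

Three amides sharing one core have been tested in an ADME assay on RAW264.7 cells (Mus musculus) for cytotoxicity, read by MTT assay, with a stated time of 48 h; a lower number here means a stronger inhibitor, a higher number a weaker inhibitor. Compound 1 `Cc1cc(NC(=O)c2ccc(Cl)cc2)ccc1NS(C)(=O)=O` gives 69100 nM in this assay. Compound 2 `Cc1cc(NC(=O)c2ccc(Cl)cc2)ccc1NS(=O)(=O)C(F)(F)F` gives 35400 nM. Compound 3 `CS(=O)(=O)Nc1ccc(NC(=O)c2ccc(Cl)cc2)cc1Cl` gives 79900 nM, the highest number of the three; its gap to compound 1 is within the scatter, while its gap to compound 2 is beyond it. Compound 4 `O=C(Nc1ccc(NS(=O)(=O)C(F)(F)F)c(Cl)c1)c1ccc(Cl)cc1` has not yet been measured. It differs from compound 3 by trifluoromethyl in place of methyl on a sulfonyl sulfur. Among the measured compounds shown here, one measured step bears directly on this change: a 2.0-fold lower number from compound 1 to compound 2 (0.29 log units; within the scatter). The other step, a 1.2-fold higher number from compound 1 to compound 3 (0.06 log units; within the scatter), shows that the chloro for methyl exchange on the aromatic carbon, which compound 3 and compound 4 both carry, left the number about where it was. On this basis compound 4 is expected to show a 2.0-fold lower number from compound 3 to compound 4 (0.30 log units; within the scatter), a step that would itself sit within the scatter. The estimate for compound 4 in this assay is 40000 nM, with a range from 18000 nM to 85000 nM.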

Compound 4, half-maximal inhibitory concentration: 47200 nM
Compound 4: middle estimate off by 1.2-fold (0.07 log units), on the low side; the range from low to high includes it.
By their numbers in this assay, from the lowest: compounds 2, 4, 1 and 3 (each within the scatter of the next, the first and the last beyond it).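

In this assay, trifluoromethyl in place of methyl on a sulfonyl sulfur, now read on a second core, gives a 1.7-fold lower number from compound 3 to compound 4 (0.23 log units; within the scatter), and the two readings match: the same change on two cores in this assay, a 2.0-fold lower number (0.29 log units; within the scatter) from compound 1 to compound 2 and a 1.7-fold lower number (0.23 log units; within the scatter) from compound 3 to compound 4, 1.2-fold (0.06 log units) apart, within the scatter of two such steps Chloro in place of methyl on an aromatic carbon, now read with trifluoromethyl on the sulfonyl sulfur, gives a 1.3-fold higher number from compound 2 to compound 4 (0.12 log units; within the scatter), and this change also repeats: the same change on two cores in this assay, a 1.2-fold higher number (0.06 log units; within the scatter) from compound 1 to compound 3 and a 1.3-fold higher number (0.12 log units; within the scatter) from compound 2 to compound 4, 1.2-fold (0.06 log units) apart, within the scatter of two such steps Each single step stays within the scatter, so what the result adds is agreement between the two cores for each change, not a firm difference between any two compounds that differ in one place.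

As far as these compounds go, whether a longer chain such as ethyl, or a phenyl ring, on the sulfonyl sulfur would move the number beyond the scatter remains open. The same question stands for an amine or a methoxy group on the aromatic carbon.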